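Swapping a Difluorophenyl for a Chlorophenyl on a Thioether

This account rests on a few compounds, and the source may have more. Where it says the series, first, only, none or still open, it means among the compounds named here.

Three compounds have been measured so far:

Compound 1, `COc1cc(-c2nnc(SCc3cccc([N+](=O)[O-])c3)o2)ccc1O`, gives 16000 nM.
Compound 2, `COc1cc(-c2nnc(SCc3ccccc3F)o2)ccc1O`, gives 5790 nM.
Compound 3, `COc1cc(-c2nnc(SCc3c(F)cccc3F)o2)ccc1O`, gives 10100 nM.

All three share one core and differ only in the aromatic ring that hangs off the sulfur-bound chain carbon. Going by the values given here, in a functional assay on cells (T-cell, Mus musculus, strain BALB/c) for inhibition, read by MTT assay, with stated times of 24 h and 72 h (on this read-out higher numbers stand for weaker inhibition and lower numbers for stronger inhibition), compound 3 stands among the other two: its number and that of compound 1 lie within the usual scatter of each other, and the one single-point step that touches it, a 1.7-fold higher number from compound 2 to compound 3 (0.24 log units; within the scatter), is also within the scatter. On the numbers shown, nothing separates compound 3 from its neighbours.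

Compound 4, `COc1cc(-c2nnc(SCc3cccc(Cl)c3)o2)ccc1O`, has not yet been measured. It differs from compound 3 by 3-chlorophenyl in place of 2,6-difluorophenyl on a saturated chain carbon bound to a sulfur. Among the compounds with values here, no measured step swaps a chlorine-bearing ring for a fluorine-bearing one, so the only guidance is that every change to this ring so far, including a 1.7-fold higher number from compound 2 to compound 3 (0.24 log units; within the scatter), has stayed within the scatter. On that basis compound 4 is expected to give about 7500 nM in this assay, somewhere between 3000 nM and 20000 nM, which means an expected step of a 1.3-fold lower number from compound 3 to compound 4 (0.13 log units; within the scatter) and no change beyond the scatter.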

Compound 4, half-maximal inhibitory concentration: 8290 nM
The estimate for compound 4 lay 1.1-fold (0.04 log units) below the measured number; the measured number falls inside the stated range.
By their numbers in this assay, from the lowest: compounds 2, 4, 3 and 1 (each within the scatter of the next, the first and the last beyond it).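

In this assay, compound 4 puts the first chlorine-bearing ring on a saturated chain carbon bound to a sulfur, and this ring cannot be told apart from any of the three rings before it (the steps are a 1.2-fold lower number from compound 3 to compound 4 (0.09 log units; within the scatter) and a 1.4-fold higher number from compound 2 to compound 4 (0.16 log units; within the scatter) and a 1.9-fold lower number from compound 1 to compound 4 (0.29 log units; within the scatter), each within the scatter). Trading 3-chlorophenyl for 2,6-difluorophenyl or 2-fluorophenyl, or chloro for nitro, therefore gives no readable change at this position, so this series of substituted phenyl rings now has four members that show no separation in any step from compound 4. No evidence is available on why these rings read alike.

On these data alone, it remains open whether any group at this position can move the number beyond the scatter, and a ring bearing an amine or a carboxylic acid, or a longer chain between the sulfur and the ring, would put that to the test. As far as these compounds go, the effect of changes to the shared core, such as replacing its hydroxyl or methoxy group, also remains open.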